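The source may hold more compounds than are shown below. What is called first, only, known or untested is meant among the compounds shown, and "the series" means these compounds.

Measured compounds:
- compound 1, `CC(C(=O)N1CCN(c2ccccc2)CC1)N1C(=O)CCC1=O`: 165 mg/kg
- compound 2, `CC(C(=O)N1CCN(c2ccccc2F)CC1)N1C(=O)CCC1=O`: 151 mg/kg
- compound 3, `CC(C(=O)N1CCN(c2ccc(F)cc2)CC1)N1C(=O)CCC1=O`: 130 mg/kg

All three were run in a functional assay on the whole organism (strain Swiss) with Mus musculus as the target, in the maximal electroshock model, with a stated time of 0.25 h; a lower number here means that less compound is needed, a higher number that more compound is needed for the effect. Compound 3 gives the lowest of the three numbers, but its separation from the others is small: the step of a 1.3-fold lower number from compound 1 to compound 3 (0.10 log units; within the scatter) and the step of a 1.2-fold lower number from compound 2 to compound 3 (0.07 log units; within the scatter) both lie within the scatter, as does the step of a 1.1-fold lower number from compound 1 to compound 2 (0.04 log units; within the scatter). On the numbers shown, the three compounds cannot be told apart.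

Compound 4, `CC(C(=O)N1CCN(c2cccc(F)c2)CC1)N1C(=O)CCC1=O`, is not yet measured. Its change from compound 3 is 3-fluorophenyl in place of 4-fluorophenyl on an amine nitrogen in a ring. Among the compounds with values here, two measured steps bear on this: the step of a 1.3-fold lower number from compound 1 to compound 3 (0.10 log units; within the scatter) introduces a fluoro on the aromatic carbon that compound 4 also carries in changed form, and the step of a 1.2-fold lower number from compound 2 to compound 3 (0.07 log units; within the scatter) moves the same fluoro between two positions on the phenyl group. Both stayed within the scatter. No step beyond the scatter is therefore expected in this assay for compound 4; the direction is left open.

The expected value for compound 4 in this assay is 140 mg/kg, with a range of 85 mg/kg to 230 mg/kg. This estimate implies a step of a 1.1-fold higher number from compound 3 to compound 4 (0.03 log units; within the scatter), which is expected to fall within the scatter.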

Compound 4, dose for half-maximal effect: 137 mg/kg
Estimate against measurement, compound 4: 1.0-fold (0.01 log units) above; low and high end bracket the measured number.
By their numbers in this assay, from the lowest: compounds 3, 4, 2 and 1 (each within the scatter of the next).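

In this assay, 3-fluorophenyl in place of 4-fluorophenyl on the amine nitrogen in a ring gives a 1.1-fold higher number from compound 3 to compound 4 (0.02 log units; within the scatter), and 3-fluorophenyl in place of 2-fluorophenyl gives a 1.1-fold lower number from compound 2 to compound 4 (0.04 log units; within the scatter), so the three fluorophenyl groups shown at this place cannot be told apart. Fluoro in place of hydrogen on an aromatic carbon gives a 1.2-fold lower number from compound 1 to compound 4 (0.08 log units; within the scatter), which means that the 3-fluorophenyl group also stays within the scatter of the unsubstituted phenyl group, and no fluoro placement shown separates from it in this series. Nothing measured here bears on why the numbers stay so close.

Still open, on these data alone, is whether a group other than fluoro on the same phenyl ring, such as chloro, methoxy, trifluoromethyl or an amine, would give a step beyond the scatter in this assay at this place. Also open, as far as these compounds go, is whether replacing the phenyl group itself with a saturated ring such as cyclohexyl, or adding a longer chain elsewhere on the shared core, would separate any compound from this tight group of four.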